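Phenoxymethyl ketone variation on a shared dipeptide core

The compounds below may be only part of what the source reports. "The series", "measured", "known", "first", "only" and "open" are said of these compounds alone.

Measured compounds:
compound 1 `CC(C)[C@H](NC(=O)COc1cccc2ccccc12)C(=O)N[C@@H](CC(=O)O)C(=O)COC(=O)c1c(Cl)cccc1Cl` — 10600 nM
compound 2 `CC(C)[C@H](NC(=O)COc1cccc2ccccc12)C(=O)N[C@@H](CC(=O)O)C(=O)COc1ccc(F)cc1` — > 100000 nM
compound 3 `CC(C)[C@H](NC(=O)COc1cccc2ccccc12)C(=O)N[C@@H](CC(=O)O)C(=O)COc1c(F)cccc1F` — 2040 nM

In a functional assay on Jurkat cells (Homo sapiens) (a higher number here means a weaker inhibitor, a lower number a stronger inhibitor), compound 3 stands lowest of the two numbers given; compound 1 is the nearest, and the step of a 5.2-fold lower number from compound 1 to compound 3 (0.72 log units; beyond the scatter) lies beyond the scatter. For compound 2 the value is a limit of this assay (the limit of > 100000 nM in this assay, at which 1 of the 3 values shown sits), not a number.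

The unmeasured compound 4 `CC(C)[C@H](NC(=O)COc1cccc2ccccc12)C(=O)N[C@@H](CC(=O)O)C(=O)COc1c(Cl)cccc1Cl` differs from compound 3 in one place: 2,6-dichlorophenyl in place of 2,6-difluorophenyl on an oxygen on a saturated carbon.

Going by the values given here, no measured step exchanges fluorine for chlorine alone. The step of an at least 49-fold lower number from compound 2 to compound 3 (1.69 log units; beyond the scatter) shows that the pattern on the phenoxy ring matters greatly, and a 5.2-fold lower number from compound 1 to compound 3 (0.72 log units; beyond the scatter) shows that moving from the dichloro ester to the difluoro ether is only a modest gain, though that step changes two things at once. Compound 4 keeps the substitution pattern that gave compound 3 its low number, so the expected step of a 1.1-fold lower number from compound 3 to compound 4 (0.05 log units; within the scatter) is small, within the scatter, with wide uncertainty in either direction. For compound 4 the estimated value in this assay is 1800 nM, with a likely range from 500 nM to 7000 nM.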

Compound 4, half-maximal inhibitory concentration: 3000 nM
Estimate against measurement, compound 4: 1.7-fold (0.22 log units) below; the range from low to high includes it.
By their numbers in this assay, from the lowest: compounds 3 and 4 (each within the scatter of the next); then compound 1. At a limit, above all of these: compound 2.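

Going by these compounds alone, with a 1.5-fold higher number from compound 3 to compound 4 (0.17 log units; within the scatter), 2,6-dichlorophenyl and 2,6-difluorophenyl on this oxygen cannot be told apart in this assay, so this is the first single exchange of the two halogens, and it leaves the number within the scatter. Within the data shown here, the an at least 33-fold lower number from compound 2 to compound 4 (1.52 log units; beyond the scatter) gives a second large step away from the 4-fluorophenyl ether, now with a different halogen, while a 3.5-fold lower number from compound 1 to compound 4 (0.55 log units; beyond the scatter) isolates what the earlier step to compound 3 could not: with 2,6-dichlorophenyl held constant, the ester carbonyl is the only change, and the ether gives the lower number, a step beyond the scatter. The value of compound 2 is a limit of the assay and not a number: the limit of > 100000 nM in this assay, at which 1 of the 4 values shown sits.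

The compounds shown leave open whether one halogen on the ring would suffice, as in 2-fluorophenyl, since compound 2 differs from compound 3 in both the number and the place of its fluorine. On these data alone, it also remains open whether halogen is needed at all, as 2,6-dimethylphenyl or an unsubstituted phenyl on the same oxygen would show, and how an amine in place of that oxygen would read.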